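A pyrazole in place of a piperazine on the benzyl arm

The source may hold more compounds than are shown below. What is called first, only, known or untested is meant among the compounds shown, and "the series" means these compounds.

Compound 1 `Cc1cc(C)c(NC(=O)N(Cc2ccc(N3CCN(C)CC3)cc2)C2CCCCCC2)c(C)c1`: > 1 mg/kg
Compound 2 `Cc1cc(C)c(NC(=O)N(Cc2cccc(-c3cc[nH]n3)c2)C2CCCCC2)c(C)c1`: 0.12 mg/kg

In a functional assay on a cell-free system (plasma) with sterol O-acyltransferase, Soat (Rattus norvegicus) as the target (a lower number here means that less compound is needed, a higher number that more compound is needed for the effect), compound 1 gives > 1 mg/kg, which is a limit of the assay and not a number (the limit of > 1 mg/kg in this assay, at which 1 of the 2 values shown sits). Compound 2 gives 0.12 mg/kg in this assay, a value well inside the measurable range. Compound 3, `Cc1cc(C)c(NC(=O)N(Cc2ccc(-c3ccnn3C)cc2)C2CCCCCC2)c(C)c1`, has not yet been measured. It differs from compound 1 in a single place: 1-methyl-1H-pyrazol-5-yl in place of 4-methylpiperazin-1-yl on an aromatic carbon. Among the measured compounds shown here, because compound 1 stands only at a limit, no measured step can be drawn from it, and compound 2 carries other differences besides the pyrazole, so its value is only a loose pointer. The expected step, an at least 3.3-fold lower number from compound 1 to compound 3 (0.52 log units; beyond the scatter), is toward a lower dose and beyond the scatter. Compound 3 is estimated at 0.3 mg/kg, with a range from 0.08 mg/kg to 1.5 mg/kg.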

Compound 3, dose for half-maximal effect: < 1 mg/kg
Compound 3: a limit, no number (the forecaster's own chance of this, stated with the estimate: 20%); the middle value does not contradict the limit.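

In this assay, placing 1-methyl-1H-pyrazol-5-yl instead of 4-methylpiperazin-1-yl on the aromatic carbon para to a large group gives a number no higher from compound 1 to compound 3 (the limit leaves the size open), the first step read at this position, and it shows that the five-membered aromatic ring is accepted there without any rise in the number. The reading for compound 3 is a limit and not a number: the limit of < 1 mg/kg in this assay, at which 1 of the 3 values shown sits. The reading for compound 1 is also a limit and not a number: the limit of > 1 mg/kg in this assay, at which 1 of the 3 values shown sits.

On these data alone, the size of the step therefore stays open, and neither compound gives a number from which it could be read. Also open, as far as these compounds go, is how a carboxylic acid or an open-chain dimethylamino group on the same aromatic carbon would read in this assay.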